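Aryl sulfone series: difluorophenyl in place of dimethylphenyl

A few compounds are considered here, and "the series" means these few. Any claim that something is new, unique, unknown or untested is made for them only; others in the source may bear on it.

Compound 1 `Cc1ccc(S(=O)(=O)c2cnc3cc(F)ccc3c2N2CCC(C)CC2)cc1C` was tested in an assay on isolated protein for displacement of a labelled ligand from metabotropic glutamate receptor 5 (Homo sapiens), with a stated time of 60 min, tested at 1 uM (a higher number here means more inhibition at the concentration tested (going by the name of the read-out), a lower number less inhibition), and gives 90%. For the measured compounds named here, the only other measured member, compound 2 `Cc1ccc(S(=O)(=O)c2cnc3c(F)cccc3c2N2CCC(C)CC2)cc1`, gives 93% in this assay; the two numbers lie within the usual scatter of each other, so no order between compound 1 and compound 2 can be read from them. Going by the values given here, no step between measured compounds that differ in one place is available, so there is no measured basis for how the sulfonyl-bound aryl group matters.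

Compound 3 `CC1CCN(c2c(S(=O)(=O)c3ccc(F)c(F)c3)cnc3cc(F)ccc23)CC1` is the next member. It differs from compound 1 in one place: 3,4-difluorophenyl in place of 3,4-dimethylphenyl on a sulfonyl sulfur

Both measured compounds sit high in this assay, and the change keeps the size of the aryl group. The step from compound 1 to compound 3 is expected to be a number 6 percentage points lower from compound 1 to compound 3 (within the scatter), a small loss not clearly beyond the scatter. Compound 3 is therefore estimated at 84% in this assay, with a range from 60% to 97%.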

Compound 3, a percentage reported as inhibition, at one concentration (the size of the read-out at that concentration, not a potency): 94%
Estimate against measurement, compound 3: 10 percentage points below, and the stated range covers the measured number.
By their numbers in this assay, from the lowest: compounds 1, 2 and 3 (each within the scatter of the next).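

For the compounds shown here, replacing 3,4-dimethylphenyl with 3,4-difluorophenyl on a sulfonyl sulfur gives the only one-place step so far: in this assay, it is a number 4 percentage points higher from compound 1 to compound 3 (within the scatter). The sulfonyl-bound aryl group can therefore carry either pair of substituents without a change that can be told from the scatter, and no order between the two groups can be claimed. No measurement shown offers an explanation for how closely these two aryl groups agree.

All three compounds are compared at a single concentration, so this step gives no potency difference between them. From the compounds shown here alone, it remains open whether a pyridyl group, a cyclohexyl group or a phenyl group carrying a methoxy or a nitrile on the sulfonyl sulfur would hold the number as well.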